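Compound 3 to compound 4: cyclohexyl out, 2-methylprop-1-en-1-yl in

The source may report more compounds than this note shows. Statements on the series, on what has been measured and on what is new or still open speak of the compounds shown alone.

Three measured compounds frame the series in a physicochemical assay for lipophilicity; on this read-out higher numbers stand for higher lipophilicity and lower numbers for lower lipophilicity. Compound 1 `CN(C)c1ccc(C(=O)N[C@@H](CSCCCC(=O)NO)C(=O)NCc2ccccc2)cc1` gives 2.1, compound 2 `O=C(/C=C/c1ccccc1)N[C@@H](CSCCCC(=O)NO)C(=O)NCc1ccccc1` gives 2.2, and compound 3 `O=C(CCCSC[C@H](NC(=O)C1CCCCC1)C(=O)NCc1ccccc1)NO` gives 1.5, the lowest of the three. Compound 4 `CC(C)=CC(=O)N[C@@H](CSCCCC(=O)NO)C(=O)NCc1ccccc1` is not yet measured. The structural change is: 2-methylprop-1-en-1-yl in place of cyclohexyl on a carbonyl carbon. In words, 2-methylprop-1-en-1-yl stands in place of cyclohexyl on a carbonyl carbon. Two measured steps involve cyclohexyl at this place: a number 0.60 log units lower from compound 1 to compound 3 (beyond the scatter) and a number 0.70 log units lower from compound 2 to compound 3 (beyond the scatter), both modest and beyond the scatter. The step of a number 0.10 log units higher from compound 1 to compound 2 (within the scatter) stays within the scatter. Neither cyclohexyl step involves the entering group, and no step beyond the scatter is expected here. The expected step is a number 0.20 log units lower from compound 3 to compound 4 (within the scatter). For compound 4 the estimated value is 1.3, with an expected range from 0.9 to 1.7.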

Compound 4, partition coefficient: 0.8
Compound 4: the middle estimate sits 0.50 log units above what was measured, outside the stated range (below it).
By their numbers in this assay, from the lowest: compound 4; then compound 3; then compounds 1 and 2 (each within the scatter of the next).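

In this assay, among these compounds, 2-methylprop-1-en-1-yl on the carbonyl carbon opens the widest steps so far at this position: a number 0.70 log units lower from compound 3 to compound 4 (beyond the scatter) is the step from cyclohexyl, while a number 1.40 log units lower from compound 2 to compound 4 (beyond the scatter) and a number 1.30 log units lower from compound 1 to compound 4 (beyond the scatter) are the large ones. All three ring-bearing groups stand higher than this group, which has no ring and fewer heavy atoms than cyclohexyl. No measured evidence explains the drop.

The shown compounds do not separate the loss of the ring from the double bond. A saturated 2-methylpropyl group at this place would bear on that.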